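Propyl to butyl: working notes on the series

The source may report more compounds than this note shows. Statements on the series, on what has been measured and on what is new or still open speak of the compounds shown alone.

Among the measured compounds shown here, in a functional assay on HeLa cells (Homo sapiens) for cytotoxicity (on this read-out lower numbers stand for stronger inhibition and higher numbers for weaker inhibition), three compounds have values so far. Compound 1 (`CCCOC1=CC(=O)c2ccccc2C1=O`) gives 51600 nM and stands highest of the three, so it is the weakest here, and its gaps to both others lie beyond the scatter. Compound 2 (`Cc1ccc(S(=O)(=O)Oc2ccc3c(c2)C(=O)C=CC3=O)cc1`) gives 15100 nM and compound 3 (`COc1ccc2c(c1)C(=O)C=CC2=O`) gives 22700 nM on the same read-out. These last two values lie within the scatter of each other.

The next compound is compound 4 (`CCCCOC1=CC(=O)c2ccccc2C1=O`), which differs from compound 1 in one place (methyl in place of hydrogen on a saturated chain carbon, three bonds along the chain from an oxygen on an unsaturated carbon). The change is methyl in place of hydrogen on a saturated chain carbon, three bonds along the chain from an oxygen on an unsaturated carbon. Cut one bond further out, it reads propyl to butyl.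

For the measured compounds named here, no two measured compounds differ in a single place, so the series gives no direct guide to the size of this step. In this assay a small move toward a lower number is expected, and it may well stay within the scatter. The estimated step (a 1.3-fold lower number from compound 1 to compound 4 (0.11 log units; within the scatter)) is correspondingly modest. For compound 4 the estimated value is 40000 nM (expected range 18000 nM to 80000 nM).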

Compound 4, half-maximal inhibitory concentration: 35300 nM
The estimate for compound 4 lay 1.1-fold (0.05 log units) above the measured number; the measured number falls inside the stated range.
By their numbers in this assay, from the lowest: compounds 2, 3, 4 and 1 (each within the scatter of the next, the first and the last beyond it).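

In this assay the propyl to butyl change reads as a 1.5-fold lower number from compound 1 to compound 4 (0.16 log units; within the scatter) and gives the series its first pair that differs in one place. At this position on the shared core, the methyl in place of hydrogen on the saturated chain carbon therefore leaves the value indistinguishable from that of the shorter chain, and a difference this size cannot be taken as a real effect of the added carbon. No measurement at hand accounts for this result.

From the compounds shown here alone, one pair cannot show a trend with chain length, so it remains open whether a longer chain such as hexyl or octyl, a branched chain such as isopropyl, or a chain ending in an amine or a carboxylic acid would give a step beyond the scatter. Among the compounds shown here, it also remains open whether the same methyl in place of hydrogen would give a similar step on the core of compound 3, where no matching pair is available.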